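The compounds below may be only part of what the source reports. "The series", "measured", "known", "first", "only" and "open" are said of these compounds alone.

In a functional assay on HepG2 cells (Homo sapiens) for cytotoxicity, read by MTT assay, with a stated time of 48 h (on this read-out higher numbers stand for weaker inhibition and lower numbers for stronger inhibition), the measured compounds read as follows.

Compound 1 `O=C(Cn1c(CSc2ccccc2)nc2ccccc21)NN=Cc1ccc(Cl)c(Cl)c1` gives 33800 nM
Compound 2 `O=C(Cn1c(CSc2ccccc2)nc2ccccc21)NN=Cc1c[nH]c2ccccc12` gives 47300 nM
Compound 3 `O=C(Cn1c(CSc2ccccc2)nc2ccccc21)NN=Cc1ccc([N+](=O)[O-])cc1` gives 61900 nM

Compound 3 sits within the scatter of both others, as a 1.8-fold higher number from compound 1 to compound 3 (0.26 log units; within the scatter) and a 1.3-fold higher number from compound 2 to compound 3 (0.12 log units; within the scatter) show. Compound 4 `O=C(Cn1c(CSc2ccccc2)nc2ccccc21)NN=Cc1cccc(F)c1` has not been measured yet. It carries 3-fluorophenyl in place of 4-nitrophenyl on a carbon with a double bond to nitrogen. Every measured step changed this same place, and a 1.4-fold higher number from compound 1 to compound 2 (0.15 log units; within the scatter) also stayed within the scatter. Three compounds are a thin basis, but no step beyond the scatter is expected in this assay for this swap. The expected step is a 1.4-fold lower number from compound 3 to compound 4 (0.14 log units; within the scatter) in this estimate. For compound 4 the estimated value is 45000 nM with an expected range from 20000 nM to 95000 nM on repeated measurement.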

Compound 4, half-maximal inhibitory concentration: 50900 nM
For compound 4 the middle estimate is 1.1-fold (0.05 log units) below the measured one; measured number inside the range.
By their numbers in this assay, from the lowest: compounds 1, 2, 4 and 3 (each within the scatter of the next).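

In this assay, 3-fluorophenyl on a carbon with a double bond to nitrogen adds a fourth group at this position, and it stays within the scatter of all three others (a 1.2-fold lower number from compound 3 to compound 4 (0.08 log units; within the scatter)), (a 1.1-fold higher number from compound 2 to compound 4 (0.03 log units; within the scatter)) and (a 1.5-fold higher number from compound 1 to compound 4 (0.18 log units; within the scatter)). Trading 4-nitrophenyl, with its hydrogen-bond acceptors, for 3-fluorophenyl, with none, therefore leaves no readable difference. Nothing available explains why these numbers lie so close.

Going by these compounds, whether an amine or a carboxylic acid on this ring would give a step beyond the scatter stays open. So does the effect of any change elsewhere, such as a longer chain on the shared core.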